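The source may hold more compounds than are shown below. What is called first, only, known or untested is meant among the compounds shown, and "the series" means these compounds.

Of the compounds shown here, three built on one shared core have been measured in a functional assay on U-87MG ATCC cells (Homo sapiens) for cytotoxicity, read by MTT assay, with a stated time of 48 h; a lower number here means a stronger inhibitor, a higher number a weaker inhibitor. Compound 1 `C/C(=N/NC(=S)Nc1cccc([N+](=O)[O-])c1)c1ccccn1` gives 69 nM in this assay. Compound 2 `C/C(=N/NC(=S)Nc1ccccc1I)c1ccccn1` gives 6.1 nM in this assay. Compound 3 `C/C(=N/NC(=S)Nc1cccc(I)c1)c1ccccn1` gives 84 nM in this assay. Compound 2 has the lowest number of the three, and its gaps to both compound 1 and compound 3 lie beyond the usual scatter of repeated measurements. Compound 2 and compound 3 contain the same atoms joined differently; the difference between the two cores is not broken down here.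

One structural change appears twice. From compound 3 to compound 1 it is nitro in place of iodo on an aromatic carbon, and the measured step is a 1.2-fold lower number from compound 3 to compound 1 (0.09 log units; within the scatter). The unmeasured compound 4 `C/C(=N/NC(=S)Nc1ccccc1[N+](=O)[O-])c1ccccn1` arises from compound 2 through (nitro in place of iodo on an aromatic carbon). The two places are not identical: in the measured pair the group sits meta to a large group, whereas in the new pair it sits ortho to a large group, so this is the same kind of change rather than the same change.

The step from compound 2 to compound 4 is expected to be a 1.5-fold higher number from compound 2 to compound 4 (0.17 log units; within the scatter), resting on the small measured step of a 1.2-fold lower number from compound 3 to compound 1 (0.09 log units; within the scatter), with extra room allowed for the different place. Compound 4 is therefore estimated at 9 nM, between 3 nM and 30 nM.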

Compound 4, half-maximal inhibitory concentration: 4.3 nM
For compound 4 the middle estimate is 2.1-fold (0.32 log units) above the measured one; measured number inside the range.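

In this assay, putting nitro in place of iodo on the aromatic carbon of compound 2 gives a 1.4-fold lower number from compound 2 to compound 4 (0.15 log units; within the scatter), so this swap leaves the number within the usual scatter, as it did on the other core. The two steps can therefore be treated as one result, and in this small set the swap carries from one core to the other without a measurable shift: the same change on two cores in this assay, a 1.2-fold lower number (0.09 log units; within the scatter) from compound 3 to compound 1 and a 1.4-fold lower number (0.15 log units; within the scatter) from compound 2 to compound 4, 1.2-fold (0.07 log units) apart, within the scatter of two such steps

Going by these compounds alone, this holds even though the two cores sit far apart, with compound 2 at 6.1 nM and compound 3 at 84 nM, but it rests on only two pairs and shows neither why the swap makes so little difference nor why those two cores give such different numbers, and it is no rule for other cores or for other groups.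

On these data alone, whether an amine, a carboxylic acid or a methoxy group on the same aromatic carbon would also leave the number in place remains open. As far as these compounds go, the rest of the shared core is the same in all four compounds, so how a change there, such as a longer chain in place of the methyl group, would act on these numbers is also open.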